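Benzyl to 2-acetoxyethyl: notes on compound 4

The source may report more compounds than this note shows. Statements on the series, on what has been measured and on what is new or still open speak of the compounds shown alone.

Measured so far in a functional assay on B16 cells (Mus musculus) for cytotoxicity, read by MTT assay, with a stated time of 48 h; on this read-out higher numbers stand for weaker inhibition and lower numbers for stronger inhibition:
- compound 1 `C#CC(=O)Nc1cccc(C#C)c1` gives 300 nM
- compound 2 `C#CCNC(=O)c1cn(CCOC(C)=O)nn1` gives > 100000 nM (a limit, not a number)
- compound 3 `C#Cc1cccc(NC(=O)c2cn(Cc3ccccc3)nn2)c1` gives 14500 nM

Compound 3 at 14500 nM carries the higher of the two actual numbers, and compound 1 is lower at 300 nM on the same read-out. Compound 2 stands at > 100000 nM as a limit only.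

Compound 4 `C#Cc1cccc(NC(=O)c2cn(CCOC(C)=O)nn2)c1` keeps the rest of compound 3 and differs by acetoxymethyl in place of phenyl on a saturated chain carbon bound to an aromatic nitrogen (acetoxymethyl in place of phenyl on a saturated chain carbon bound to an aromatic nitrogen, which, cut one bond further out, reads benzyl to 2-acetoxyethyl). Among the compounds with values here, no measured pair isolates this change.

In this assay a step toward a higher number is expected, beyond the scatter. Within the data shown here, the only hint is compound 2, which also bears 2-acetoxyethyl, at > 100000 nM as a limit. The expected step is a 2.4-fold higher number from compound 3 to compound 4 (0.38 log units; beyond the scatter) and remains loosely founded. For compound 4 the estimate is 35000 nM with an expected range from 8000 nM to 100000 nM on this read-out.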

Compound 4, half-maximal inhibitory concentration: 25100 nM
Estimate against measurement, compound 4: 1.4-fold (0.14 log units) above; the measured number falls inside the stated range.
By their numbers in this assay, from the lowest: compound 1; then compounds 3 and 4 (each within the scatter of the next). At a limit, above all of these: compound 2.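

In this assay, the change reads as a 1.7-fold higher number from compound 3 to compound 4 (0.24 log units; within the scatter), so benzyl and 2-acetoxyethyl cannot be told apart at this position. For this pair, therefore, a phenyl on the saturated chain carbon bound to an aromatic nitrogen is not required to keep the number in this range, and a chain holding an ester with no ring reads the same. Compound 2 also bears 2-acetoxyethyl but is known only as a limit of the assay: the limit of > 100000 nM in this assay, at which 1 of the 4 values shown sits.

One pair cannot show whether this tolerance extends to other groups, such as 2-hydroxyethyl, 2-aminoethyl, a carboxylic acid or a longer alkyl chain at the same place. Also open, as far as these compounds go, is whether any group here can bring the shared core close to compound 1 at 300 nM.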